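From isopropyl to cyclopropylmethyl on a ring amine nitrogen

The source may report more compounds than this note shows. Statements on the series, on what has been measured and on what is new or still open speak of the compounds shown alone.

Four compounds share closely related structures, and three of them have been tested in a functional assay (strain AB) with Danio rerio as the target, read by microscopy, with a stated time of 1 h; a higher number here means that more compound is needed for the effect, a lower number that less compound is needed. Compound 1 (`CCC1CCc2c(sc(NC(=O)Nc3ccc(Cl)cc3)c2C(N)=O)C1`) reached only a limit of the assay (> 25000 nM) and not a number. Compound 3 (`CCN1CCc2c(sc(NC(=O)Nc3ccc(Cl)cc3)c2C#N)C1`) likewise reached only a limit (> 25000 nM). Among the measured compounds shown here, that leaves compound 2 (`CC(C)[N+]1(C)CCc2c(sc(NC(=O)Nc3ccc(Cl)cc3)c2C(N)=O)C1`) at 960 nM as the only true number available.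

Compound 4 (`C[N+]1(CC2CC2)CCc2c(sc(NC(=O)Nc3ccc(Cl)cc3)c2C(N)=O)C1`) has not yet been measured. It carries cyclopropylmethyl in place of isopropyl on an amine nitrogen in a ring. For the measured compounds named here, no measured pair of compounds shows what a change at this place does, so the expectation rests on compound 2 (960 nM) alone. The expected change, a 1.0-fold higher number from compound 2 to compound 4 (0.02 log units; within the scatter) in this assay, is small, with no clear direction and nothing beyond the scatter. Compound 4 is estimated at 1000 nM, with an expected range from 300 nM to 3500 nM in the coming measurement.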

Compound 4, half-maximal effective concentration: 360 nM
For compound 4 the middle estimate is 2.8-fold (0.44 log units) above the measured one; measured number inside the range.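

Replacing isopropyl with cyclopropylmethyl on the amine nitrogen in a ring gives a 2.7-fold lower number from compound 2 to compound 4 (0.43 log units; beyond the scatter) in this assay. Among the compounds shown here, this is the first reading of a change at this place, and although modest, it lies beyond the scatter, so the group carried on this nitrogen does matter in this assay. Less compound is needed for the effect with cyclopropylmethyl, which brings one more carbon and a three-membered ring than isopropyl.

The two changes arrive together, so the compounds shown do not separate the extra carbon from the ring, and a straight butyl chain on the same nitrogen would speak to that. Compound 1 and compound 3 offer only a limit and no number against which this step could be set: the limit of > 25000 nM in this assay, at which 2 of the 4 values shown sit.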